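The compounds below may be only part of what the source reports. "The series", "measured", "known", "first", "only" and "open" are said of these compounds alone.

Measured compounds:
compound 1, `COc1cccc(N2CCN(C(=O)C(C)N3C(=O)CCC3=O)CC2)c1`, 50%;
compound 2, `CCC(C(=O)N1CCN(c2cccc(OC)c2)CC1)N1C(=O)CCC1=O`, 0%.

In a functional assay on the whole organism (strain Swiss) with Mus musculus as the target, in the maximal electroshock model, with a stated time of 0.5 h, at a dose of 300 mg/kg by the intraperitoneal route (on this read-out lower numbers stand for a weaker effect and higher numbers for a stronger effect at the one dose given), compound 1 gives 50%, the higher of the two numbers recorded. For the measured compounds named here, the only measured step is a number 50 percentage points lower from compound 1 to compound 2 (beyond the scatter), and it comes from a change on the saturated chain, not on the aromatic ring. Compound 3, `CC(C(=O)N1CCN(c2cccc(C(F)(F)F)c2)CC1)N1C(=O)CCC1=O`, is not yet measured. It differs from compound 1 by trifluoromethyl in place of methoxy on an aromatic carbon. The group sits on an aromatic carbon of a six-membered aromatic ring of carbon only, meta to a large group. Going by the values given here, no measured pair shows what a change at that position does, so the step from compound 1 to compound 2 gives no guidance of direction here; it only shows that this series can fall far on a small change. With nothing bearing on the aromatic substituent, the expectation for compound 3 is that it stays near compound 1, with a wide range; the expected step is no change at the digits printed from compound 1 to compound 3 (within the scatter). Compound 3 is therefore estimated at 50%, between 10% and 90%.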

Compound 3, a percentage reported as activity, at one dose (the size of the read-out at that dose, not a potency): 100%
Compound 3: the middle estimate sits 50 percentage points below what was measured, and the stated range ends below it.
By their numbers in this assay, from the lowest: compound 2; then compound 1; then compound 3.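

In this assay, the aromatic carbon carrying the substituent proves to be a position that matters: trifluoromethyl in place of methoxy gives a number 50 percentage points higher from compound 1 to compound 3 (beyond the scatter). Until this result, the only measured step, a number 50 percentage points lower from compound 1 to compound 2 (beyond the scatter), lay on the saturated chain and pointed downward, so the series had shown only that it could lose its effect on a small change. The aromatic substituent now shows that a single change elsewhere on the core of compound 1 can also move the number upward, and by a large step, although nothing measured here accounts for this.

Only one replacement at this aromatic carbon is shown, so it remains open whether plain hydrogen, chlorine or a nitrile in the same place would sit nearer to methoxy or to trifluoromethyl, and so whether the step follows from gaining the one group or from losing the other. Also open is whether trifluoromethyl would keep its effect on the longer chain of compound 2, where the methoxy compound gives 0%, since the two changes appear together in no compound shown.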